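The source may report more compounds than this note shows. Statements on the series, on what has been measured and on what is new or still open speak of the compounds shown alone.

Measured compounds:
compound 1, `Cc1[nH]c(=O)n(C)c1-c1ccc(CC(C)C)cc1`, gives 30 mg/kg
compound 2, `CCCCCCc1ccc(-c2c(C)[nH]c(=O)n2C)cc1`, gives 0.3 mg/kg

The read-out throughout is a functional assay on the whole organism with Rattus norvegicus as the target; on this read-out lower numbers stand for an effect already at smaller amounts and higher numbers for an effect only at larger amounts of compound. Within the data shown here, compound 2 stands at the lowest of the two numbers seen so far; its only neighbor is compound 1, and the single measured step between them, a 100-fold lower number from compound 1 to compound 2 (2.00 log units; beyond the scatter), came with pentyl in place of isopropyl on a saturated chain carbon bound to an aromatic carbon.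

Compound 3, `Cc1[nH]c(=O)n(C)c1-c1ccc(C2CCCCC2)cc1`, has not been measured. It differs from compound 2 by cyclohexyl in place of hexyl on an aromatic carbon. The measured step concerns a longer chain at this place, not the closing of a chain into a ring, so it bears on the new change only loosely: it shows that the group at this place matters a great deal, but not which way a ring will go. A small step toward larger amounts, a 3.3-fold higher number from compound 2 to compound 3 (0.52 log units; beyond the scatter), is therefore expected. Compound 3 is estimated at 1 mg/kg, with a range from 0.3 mg/kg to 10 mg/kg.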

Compound 3, minimum effective dose: 0.1 mg/kg
Compound 3: middle estimate off by 10-fold (1.00 log units), on the high side; measured number below the stated range.
By their numbers in this assay, from the lowest: compound 3; then compound 2; then compound 1.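

In this assay, closing the chain into a ring at this place cost nothing: with six carbons on each side, cyclohexyl in place of hexyl brought a further drop in the dose needed (a 3.0-fold lower number from compound 2 to compound 3 (0.48 log units; beyond the scatter)). An open, long chain is therefore not required for a low number here, and the ring does better than the hexyl chain; measured against the shorter branched group of compound 1, the change is much larger (a 300-fold lower number from compound 1 to compound 3 (2.48 log units; beyond the scatter)). Nothing available explains why the ring outperforms the chain.

The compounds shown leave open whether a smaller ring such as cyclopentyl, or a flat phenyl ring, would hold this low number. Going by these compounds, all the groups here are carbon alone, so what an amine, an ether chain or a carboxylic acid would do at this place also remains open.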